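The compounds below may be only part of what the source reports. "The series", "measured", "known", "first", "only" and "open" are said of these compounds alone.

Compound 1, whose structure is `O=C(O)C[C@H](O)C[C@H](O)CCn1c(-c2ccc(F)cc2)nc(C(=O)NCc2cccc(F)c2)c1C1CC1`, was tested in an assay on microsomes from liver for inhibition of 3-hydroxy-3-methylglutaryl-coenzyme A reductase (Rattus norvegicus), read by scintillation counting, with stated times of 0.5 h and 0.75 h (a higher number here means a weaker inhibitor, a lower number a stronger inhibitor), where compound 1 gives 1.2 nM. Among the measured compounds shown here, this is the lower of the two numbers measured so far. The other measured compound, compound 2, with structure `Cc1c(C(=O)NCc2ccccc2)nc(-c2ccc(F)cc2)n1CC[C@@H](O)C[C@@H](O)CC(=O)O`, gives 94 nM in this assay. For the measured compounds named here, compound 2 differs from compound 1 in more than one place, so these two values show only that compound 1 is the stronger inhibitor of the pair, by a margin well beyond the usual scatter.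

Compound 3, with structure `COc1ccccc1CNC(=O)c1nc(-c2ccc(F)cc2)n(CC[C@@H](O)C[C@@H](O)CC(=O)O)c1C1CC1`, has not yet been measured in this assay. It differs from compound 1 in a single place: 2-methoxyphenyl in place of 3-fluorophenyl on a saturated chain carbon bound to an amide-type nitrogen. The rest of the molecule is kept. Going by the values given here, no measured pair shows this exact change, so the expectation rests on compound 1 alone: a small step, if any, one that may well lie within the scatter, leaning toward a slightly higher number. The step from compound 1 to compound 3 is therefore expected to be a 2.5-fold higher number from compound 1 to compound 3 (0.40 log units; beyond the scatter). Compound 3 is estimated at 3 nM, with a range from 0.8 nM to 12 nM.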

Compound 3, half-maximal inhibitory concentration: 7 nM
Compound 3: middle estimate off by 2.3-fold (0.37 log units), on the low side; the range from low to high includes it.
By their numbers in this assay, from the lowest: compound 1; then compound 3; then compound 2.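

Replacing 3-fluorophenyl with 2-methoxyphenyl on a saturated chain carbon bound to an amide-type nitrogen gives, in this assay, a 5.8-fold higher number from compound 1 to compound 3 (0.77 log units; beyond the scatter), a step beyond the usual scatter, so the measured inhibition does respond to a change at this place. The change weakens inhibition but does not remove it, as compound 3 still gives 7 nM, so a 2-methoxybenzyl group on the amide nitrogen remains compatible with strong inhibition on the core of compound 1. No accompanying measurement accounts for the size of this step.

This single swap alters two things at once, the kind of group on the ring, fluoro or methoxy, and its numbered place, so it cannot show which of the two matters more. Going by these compounds, the 2-fluorophenyl and 3-methoxyphenyl groups would separate these two changes, and an unsubstituted phenyl would show what either group adds or costs relative to a ring carrying neither, so all three remain open at this place on the same core.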